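Replacing 4-nitrophenyl with pyridin-3-yl on a carbonyl carbon

The source may report more compounds than this note shows. Statements on the series, on what has been measured and on what is new or still open speak of the compounds shown alone.

Measured in a functional assay on MCF7 cells (Homo sapiens) for antiproliferative activity, with a stated time of 5 days; a higher number here means a weaker inhibitor, a lower number a stronger inhibitor:
Compound 1 `CCCCc1ccc2[nH]c(-c3ccc(OC)cc3)c(/C=N/O)c2c1`: 212 nM
Compound 2 `CCCCc1ccc2[nH]c(-c3ccc(OC)cc3)c(/C=N/NC(=O)c3ccccc3)c2c1`: 130 nM
Compound 3 `CCCCc1ccc2[nH]c(-c3ccc(OC)cc3)c(/C=N/NC(=O)c3ccc([N+](=O)[O-])cc3)c2c1`: 312 nM

Compound 3, at 312 nM, lies within the scatter of compound 1 and sits above compound 2, the record showing a 2.4-fold higher number from compound 2 to compound 3 (0.38 log units; beyond the scatter). Compound 4 `CCCCc1ccc2[nH]c(-c3ccc(OC)cc3)c(/C=N/NC(=O)c3cccnc3)c2c1` has not yet been measured. It differs from compound 3 by pyridin-3-yl in place of 4-nitrophenyl on a carbonyl carbon. The closest guide is the nitro step, a 2.4-fold higher number from compound 2 to compound 3 (0.38 log units; beyond the scatter), which the change removes. The other step, a 1.6-fold lower number from compound 1 to compound 2 (0.21 log units; within the scatter), stays within the scatter and says little here. For the measured compounds named here, no measured compound carries pyridin-3-yl, so the guide is only partial. A modest estimated step is expected in this assay, a 1.8-fold lower number from compound 3 to compound 4 (0.26 log units; within the scatter). Compound 4 is expected at about 170 nM, with an estimated range of 80 nM to 350 nM.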

Compound 4, half-maximal inhibitory concentration: 75 nM
Compound 4: the middle estimate sits 2.3-fold (0.36 log units) above what was measured; measured number below the stated range.
By their numbers in this assay, from the lowest: compounds 4, 2, 1 and 3 (each within the scatter of the next, the first and the last beyond it).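

In this assay, pyridin-3-yl in place of 4-nitrophenyl on the carbonyl carbon gives a 4.2-fold lower number from compound 3 to compound 4 (0.62 log units; beyond the scatter) and moves compound 4 clear of compound 3. Against the plain phenyl group, a 1.7-fold lower number from compound 2 to compound 4 (0.24 log units; within the scatter) leaves the ring nitrogen with no effect that can be told from scatter. The step from the hydroxy group, a 2.8-fold lower number from compound 1 to compound 4 (0.45 log units; beyond the scatter), clears the scatter, which the benzamido group alone did not do.

As far as these compounds go, whether pyridin-4-yl or 4-aminophenyl on the same carbonyl carbon would match pyridin-3-yl remains open. Nothing given here explains these steps.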